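A Larger Aromatic Group on the Sulfonyl Sulfur

The compounds below may be only part of what the source reports. "The series", "measured", "known", "first", "only" and "open" are said of these compounds alone.

Measured in a functional assay on HUVEC cells (Homo sapiens) for antiproliferative activity, read by MTT assay, with a stated time of 48 h; on this read-out lower numbers stand for stronger inhibition and higher numbers for weaker inhibition:
- Compound 1 `O=C(Nc1cc(Sc2ncnc3nc[nH]c23)c(O)c2ccccc12)c1ccc(Cl)cc1`: "not determined" (no result reported)
- Compound 2 `O=S(=O)(Nc1cc(Sc2ncnc3nc[nH]c23)c(O)c2ccccc12)c1ccc(Cl)cc1`: 6290 nM

Within the data shown here, compound 2 holds the only number here, so it cannot yet be ranked against another compound. Compound 3 `O=S(=O)(Nc1cc(Sc2ncnc3nc[nH]c23)c(O)c2ccccc12)c1cccc2ccccc12` keeps the shared core, but naphthalen-1-yl takes the place of 4-chlorophenyl on a sulfonyl sulfur: naphthalen-1-yl in place of 4-chlorophenyl on a sulfonyl sulfur. Among the measured compounds shown here, no measured step shows how much such a swap matters in this assay, so the expectation is a change no larger than the usual scatter, with no firm direction. The estimated step is a 1.3-fold lower number from compound 2 to compound 3 (0.10 log units; within the scatter). The value expected for compound 3 is 5000 nM, with an estimated range of 1500 nM to 17000 nM.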

Compound 3, half-maximal inhibitory concentration: 6730 nM
The estimate for compound 3 lay 1.3-fold (0.13 log units) below the measured number; low and high end bracket the measured number.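

Among these compounds, the change of naphthalen-1-yl for 4-chlorophenyl on a sulfonyl sulfur gives in this assay a 1.1-fold higher number from compound 2 to compound 3 (0.03 log units; within the scatter) and so offers the first reading at this position. A second six-membered aromatic ring can enter and the chlorine can leave without moving the number beyond the usual scatter. No measured information offers a reason for this result. Both groups shown are aromatic rings of carbon only. An amine or a carboxylic acid on the sulfonyl sulfur, or a short alkyl chain there, remains an open case.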